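The source may report more compounds than this note shows. Statements on the series, on what has been measured and on what is new or still open speak of the compounds shown alone.

Measured compounds:
- compound 1 `CCc1nc2ccccc2n1CCCCOc1cccc(Cl)c1`: 22 uM
- compound 2 `CCc1nc2ccccc2n1CCCCOc1cc(C)c(Cl)c([N+](=O)[O-])c1`: 18 uM
- compound 3 `CCc1nc2ccc(C)cc2n1CCCNc1ccc(Br)c(C)c1`: 27 uM

All three numbers come from an ADME assay on Vero cells (Chlorocebus sabaeus) for cytotoxicity, read by luminescence, with a stated time of 2 days; on this read-out lower numbers stand for higher toxicity in this test and higher numbers for lower toxicity in this test. Compound 1 holds the second highest of the three; compound 2 lies nearest to it and compound 3 furthest, yet both gaps fall within the usual scatter of this assay, so the three compounds cannot be told apart on this read-out.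

Compound 4 `CCc1nc2ccccc2n1CCCCOC` has not yet been tested. It differs from compound 1 in one place: methyl in place of 3-chlorophenyl on an oxygen on a saturated carbon. For the measured compounds named here, no pair of measured compounds shows a comparable change, so the data offer no direct guide for this step. A small step toward a higher number, that is toward lower toxicity, is expected, with the step from compound 1 to compound 4 estimated as a 1.8-fold higher number from compound 1 to compound 4 (0.26 log units; within the scatter). Compound 4 is estimated at 40 uM, with a range from 15 uM to 110 uM.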

Compound 4, half-maximal toxic concentration: > 50 uM
Compound 4 was reported as a limit (the forecaster's own chance of this, stated with the estimate: 20%); at least 1.2-fold (0.09 log units) between middle value and limit.
By their numbers in this assay, from the lowest: compounds 2, 1 and 3 (each within the scatter of the next). At a limit, above all of these: compound 4.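

Methyl in place of 3-chlorophenyl on an oxygen on a saturated carbon gives an at least 2.2-fold higher number from compound 1 to compound 4 (0.35 log units; beyond the scatter) in this assay. For the compounds shown here, the earlier compounds all lay within the scatter of one another, so this is the first sign that the group at this place can shift the read-out. Compound 4 is reported only as a limit, so the step gives a minimum and not a size: the limit of > 50 uM in this assay, at which 1 of the 4 values shown sits.

The compounds shown leave open whether the step follows the loss of the chlorine or of the aromatic ring, which a plain phenyl on the same oxygen would separate. Going by these compounds, how an amine or a carboxylic acid at this place would read also stays open.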